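This account rests on a few compounds, and the source may have more. Where it says the series, first, only, none or still open, it means among the compounds named here.

Three compounds share a core built from a fused two-ring system carrying a small three-membered ring, with an amide on a short chain. In an assay on NIH3T3 cells with melatonin receptor type 1A (Homo sapiens) as the target (on this read-out lower numbers stand for stronger inhibition and higher numbers for weaker inhibition), compound 1 `CCCC(=O)NC[C@@H]1C[C@H]1c1cccc2nc(CC)oc12` gives 0.05 nM. In this assay compound 2 `CCC1Nc2cccc([C@@H]3C[C@H]3CNC(=O)C(C)C)c2O1` gives 0.2 nM. In this assay compound 3 `CCCC(=O)NC[C@@H]1C[C@H]1c1cccc2c1OC(CCC)N2` gives 0.94 nM, the highest of the three numbers; its nearest neighbour is compound 2 and its furthest is compound 1, both gaps lying beyond the usual scatter. Compounds 1 and 2 differ from compound 3 in more than one place, so no single structural step can be read from their values.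

Compound 4 `CCCC1Nc2cccc([C@@H]3C[C@H]3CNC(=O)C(C)C)c2O1` is so far unmeasured. It keeps every atom of compound 3 and changes one thing: isopropyl in place of propyl on a carbonyl carbon. Nothing measured here isolates this particular change, because compound 2, which carries the same branched amide as compound 4, also differs from compound 1 elsewhere in its core. Compound 4 is therefore expected to stay close to compound 3, with the step of a 1.6-fold higher number from compound 3 to compound 4 (0.20 log units; within the scatter) being modest and possibly within the scatter. The estimate for compound 4 is 1.5 nM, within a range from 0.4 nM to 6 nM.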

Compound 4, inhibition constant: 4.9 nM
The estimate for compound 4 lay 3.3-fold (0.51 log units) below the measured number; measured number inside the range.
By their numbers in this assay, from the lowest: compound 1; then compound 2; then compound 3; then compound 4.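

In this assay, isopropyl in place of propyl on a carbonyl carbon, whose other neighbour is an amide-type nitrogen, gives a 5.2-fold higher number from compound 3 to compound 4 (0.72 log units; beyond the scatter), so simply rearranging the same three carbons at this position weakens inhibition beyond the usual scatter. The other end of compound 4 also matters: methyl in place of hydrogen on a saturated chain carbon, two bonds along the chain from a saturated ring carbon, gives a 25-fold higher number from compound 2 to compound 4 (1.39 log units; beyond the scatter), a large step that shows this single added carbon is far from neutral when the isopropyl group is present. Nothing available here accounts for either step.

From the compounds shown here alone, each change is seen only once, so it remains open whether isopropyl in place of propyl would weaken inhibition to a similar degree on the core of compound 1, or whether the added methyl would matter as much alongside the unbranched propyl amide. Going by these compounds, it also remains open how other groups on the same carbonyl carbon, such as tert-butyl or a longer chain like pentyl, would compare.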